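The compounds below may be only part of what the source reports. "The series", "measured", "known", "first", "only" and "open" are said of these compounds alone.

Measured so far in a physicochemical assay for lipophilicity; on this read-out higher numbers stand for higher lipophilicity and lower numbers for lower lipophilicity:
compound 1 `CCCCCCCCCCCCS(=O)(=O)c1ccc(O)c(C(=O)Nc2ccc(C(F)(F)F)cc2)c1` — 6.2
compound 2 `CCCCCCCCCCCCS(=O)(=O)c1ccc(O)c(C(=O)Nc2ccc(Br)cc2)c1` — 6.49
compound 3 `CCCCCCS(=O)(=O)c1ccc(O)c(C(=O)Nc2ccc(Br)cc2)c1` — 3.2

Compound 1 stands second highest of the three numbers in this assay; the nearest is compound 2, with a number 0.29 log units higher from compound 1 to compound 2 (within the scatter), and the furthest is compound 3, whose value 3.2 lies well under that of compound 1.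

Compound 4 `CS(=O)(=O)c1ccc(O)c(C(=O)Nc2ccc(C(F)(F)F)cc2)c1` differs from compound 1 in one place: hydrogen in place of undecyl on a saturated chain carbon bound to a sulfonyl sulfur. The step that bears on this is the shortening of the chain at the sulfonyl sulfur, a number 3.29 log units lower from compound 2 to compound 3 (beyond the scatter). The present change removes a longer chain still, so a large drop in this assay is expected, plausibly larger than that step; the size past it is uncertain. Compound 4 is therefore estimated at 1.2 (range 0 to 2.6), which means an expected step of a number 5.00 log units lower from compound 1 to compound 4 (beyond the scatter).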

Compound 4, distribution coefficient: 1.48
The estimate for compound 4 lay 0.28 log units below the measured number, and the stated range covers the measured number.
By their numbers in this assay, from the lowest: compound 4; then compound 3; then compounds 1 and 2 (each within the scatter of the next).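

In this assay, replacing undecyl with hydrogen on the saturated chain carbon bound to a sulfonyl sulfur gives a number 4.72 log units lower from compound 1 to compound 4 (beyond the scatter). A large drop on changing the chain is thus seen with trifluoromethyl on the aromatic carbon as well as with bromo. Nothing available bears on the origin of this step. On these data alone, how the number runs across chain lengths between undecyl and hydrogen remains open, and compound 3 and compound 4 differ in more than one place. Also open, as far as these compounds go, is what a longer chain, or a chain carrying an amine or a carboxylic acid, would give.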